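Methyl in place of bromo on the fused benzene ring

The source may report more compounds than this note shows. Statements on the series, on what has been measured and on what is new or still open speak of the compounds shown alone.

Compound 1 `CN1C(=O)C(O)(Cc2nnn[nH]2)c2ccccc21` gives 44800 nM in a functional assay on PC-3 cells (Homo sapiens) for antiproliferative activity, read by MTT assay, with a stated time of 48 h; on this read-out higher numbers stand for weaker inhibition and lower numbers for stronger inhibition. Compound 2 `CN1C(=O)C(O)(Cc2nnn[nH]2)c2cc(Cl)ccc21` returns only the limit > 100000 nM in this assay. Compound 3 `CN1C(=O)C(O)(Cc2nnn[nH]2)c2cc(Br)ccc21` likewise returns only the limit > 100000 nM in this assay. Compound 3 thus stands at the limit of > 100000 nM in this assay, at which 2 of the 3 values shown sit, with no number of its own. Compound 4 `Cc1ccc2c(c1)C(O)(Cc1nnn[nH]1)C(=O)N2C` differs from it by methyl in place of bromo on an aromatic carbon. The measured steps bearing on this position are an at least 2.2-fold higher number from compound 1 to compound 2 (0.34 log units; beyond the scatter) and an at least 2.2-fold higher number from compound 1 to compound 3 (0.34 log units; beyond the scatter), both halogens weakening inhibition against the unsubstituted parent, while a step that the two limits leave unreadable from compound 2 to compound 3. Within the data shown here, no measured step involves methyl, so its effect is open. Compound 4 is expected to stay weak, with an estimated step of an at least 1.1-fold lower number from compound 3 to compound 4 (0.04 log units; that floor lies within the scatter). Compound 4 is estimated at 90000 nM, expected between 30000 nM and 300000 nM.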

Compound 4, half-maximal inhibitory concentration: > 100000 nM
Compound 4 gave a limit, no number; the forecaster's own chance of this, stated with the estimate: 55%; at least 1.1-fold (0.04 log units) between middle value and limit.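

Methyl on this aromatic carbon gives an at least 2.2-fold higher number from compound 1 to compound 4 (0.34 log units; beyond the scatter) in this assay, so the loss seen with chloro and bromo is not confined to halogens. Compound 4 returns a limit and not a number, so the steps among compounds 2, 3 and 4 cannot be read and no order among methyl, chloro and bromo follows: the limit of > 100000 nM in this assay, at which 3 of the 4 values shown sit.

As far as these compounds go, how far these three compounds lie past that limit stays open. Also open, from the compounds shown here alone, is whether fluoro, methoxy or an amine on this carbon would stay near compound 1 or also reach the limit.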